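Working notes: chloro placement on the ester in this series

The compounds below may be only part of what the source reports. "The series", "measured", "known", "first", "only" and "open" are said of these compounds alone.

Measured compounds:
compound 1 `COC(=O)c1c(F)cccc1OC(=O)COc1cc(O)c2c(=O)cc(-c3ccccc3)oc2c1` — a functional assay on cells (T-cell, Mus musculus, strain BALB/c) for inhibition, read by MTT assay, with a stated time of 72 h; on this read-out higher numbers stand for weaker inhibition and lower numbers for stronger inhibition: 40300 nM
compound 2 `COC(=O)c1cc(Cl)ccc1OC(=O)COc1cc(O)c2c(=O)cc(-c3ccccc3)oc2c1` — 3740 nM
compound 3 `COC(=O)c1cc(F)ccc1OC(=O)COc1cc(O)c2c(=O)cc(-c3ccccc3)oc2c1` — 6820 nM

Compound 2 gives the lowest number of the three. Compound 3 lies within the scatter of it a 1.8-fold higher number from compound 2 to compound 3 (0.26 log units; within the scatter), while compound 1 stands well apart an 11-fold lower number from compound 1 to compound 2 (1.03 log units; beyond the scatter).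

Compound 4 `COC(=O)c1c(Cl)cccc1OC(=O)COc1cc(O)c2c(=O)cc(-c3ccccc3)oc2c1` differs from compound 2 by 3-chloro-2-(methoxycarbonyl)phenyl in place of 4-chloro-2-(methoxycarbonyl)phenyl on an oxygen next to a carbonyl group.

Among the measured compounds shown here, two measured steps bear on this. The corresponding relocation of fluorine, in the reverse direction, gave a 5.9-fold lower number from compound 1 to compound 3 (0.77 log units; beyond the scatter), a modest change. Exchanging the halogens themselves gave a 1.8-fold higher number from compound 2 to compound 3 (0.26 log units; within the scatter), within the scatter. A modest rise is therefore expected for compound 4, of about the size seen between compound 1 and compound 3.

Compound 4 is estimated at 20000 nM, range 7000 nM to 55000 nM. This estimate means an expected step of a 5.3-fold higher number from compound 2 to compound 4 (0.73 log units; beyond the scatter).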

Compound 4, half-maximal inhibitory concentration: 38900 nM
Compound 4: middle estimate off by 1.9-fold (0.29 log units), on the low side; measured number inside the range.
By their numbers in this assay, from the lowest: compounds 2 and 3 (each within the scatter of the next); then compounds 4 and 1 (each within the scatter of the next).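

In this assay, the 3-chloro-2-(methoxycarbonyl)phenyl group in place of 4-chloro-2-(methoxycarbonyl)phenyl gives a 10-fold higher number from compound 2 to compound 4 (1.02 log units; beyond the scatter), and against the fluoro compound 3 the step is a 5.7-fold higher number from compound 3 to compound 4 (0.76 log units; beyond the scatter), so the halogen's placement on this ring separates the compounds with chloro as well as with fluoro. Chloro in place of fluoro gives a 1.0-fold lower number from compound 1 to compound 4 (0.02 log units; within the scatter), so the choice of halogen does not separate this pair. The halogen exchange reads alike on both arrangements: the same change on two cores in this assay, a 1.8-fold higher number (0.26 log units; within the scatter) from compound 2 to compound 3 and a 1.0-fold higher number (0.02 log units; within the scatter) from compound 4 to compound 1, 1.8-fold (0.25 log units) apart, within the scatter of two such steps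

From the compounds shown here alone, how an amine or a methoxy group on this ring would read at either placement stays open. So does a carboxylic acid in place of the methoxycarbonyl group.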